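A few compounds are considered here, and "the series" means these few. Any claim that something is new, unique, unknown or untested is made for them only; others in the source may bear on it.

Of the compounds shown here, two that share one core have so far been measured in a functional assay on EA.hy 926 cells (Homo sapiens) for cytotoxicity, read by MTT assay, with stated times of 24 h and 12 h, tested at 25 uM; a higher number here means a stronger effect of the compound at the concentration tested, a lower number a weaker effect. Compound 1 `Cc1nc(C)c(C(=O)Oc2ccccc2/C=C/C(=O)O)nc1C` gives 61.8% in this assay. Compound 2 `COc1ccc(/C=C/C(=O)O)c(OC(=O)c2nc(C)c(C)nc2C)c1` gives -52.1% in this assay. Among the compounds with values here, the single measured step, a number 113.9 percentage points lower from compound 1 to compound 2 (beyond the scatter), is a large drop and lies beyond the scatter. Compound 2 therefore stands at the lower of the two measured numbers, with compound 1 well above it.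

Compound 3 `CCOC(=O)/C=C/c1ccc(OC)cc1OC(=O)c1nc(C)c(C)nc1C` has not yet been measured. Compared with compound 2 it differs in one place: ethyl in place of hydrogen on an oxygen next to a carbonyl group. Read one bond further out, carboxy becomes ethoxycarbonyl.

Within the data shown here, no measured step involves a change of this kind. Among the measured compounds shown here, the only step available, a number 113.9 percentage points lower from compound 1 to compound 2 (beyond the scatter), concerns a methoxy entering on an aromatic carbon and says nothing about an ethyl entering on an oxygen. The expectation for compound 3 therefore rests on weak footing, and no direction can be read from the data. Compound 3 is estimated at -30%, within a range from -85% to 40%. This estimate implies an expected step of a number 22.1 percentage points higher from compound 2 to compound 3 (beyond the scatter), with wide uncertainty in either direction.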

Compound 3, a percentage reported as activity, at one concentration (the size of the read-out at that concentration, not a potency): 16.9%
Compound 3: the middle estimate sits 46.9 percentage points below what was measured; the range from low to high includes it.
By their numbers in this assay, from the lowest: compound 2; then compound 3; then compound 1.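

In this assay, the change of carboxy to ethoxycarbonyl brings a number 69 percentage points higher from compound 2 to compound 3 (beyond the scatter) and is large, so this end of the molecule matters as well as the aromatic carbon that carries the methoxy in the earlier step. The change also crosses zero, from compound 2 at -52.1% on the negative side to compound 3 at 16.9% on the positive side, which shows that capping the free carboxy group with ethyl is enough on its own to turn a negative reading into a positive one within this methoxy-bearing series. No measurement at hand explains why this change acts as it does.

Only one ester is shown, so it remains open whether a methyl ester, a longer chain such as butyl on the same oxygen, or an amide in place of the ester would move the number in the same direction and by a similar amount. As far as these compounds go, it also remains open whether the ethyl group would bring a similar step on the core of compound 1, which has hydrogen where compound 2 has methoxy.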